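This account rests on a few compounds, and the source may have more. Where it says the series, first, only, none or still open, it means among the compounds named here.

Measured compounds:
Compound 1, `CC(C)=CCc1cc(C(=O)Nc2cc3ccc(OCC4CCN(C)C4)c(C)c3oc2=O)ccc1O`, gives 920 nM in a functional assay on SK-BR-3 cells (Homo sapiens) for antiproliferative activity; on this read-out lower numbers stand for stronger inhibition and higher numbers for weaker inhibition.
Compound 2, `CC(C)=CCc1cc(C(=O)Nc2cc3ccc(OCCCNCC(C)C)c(C)c3oc2=O)ccc1O`, gives 1030 nM.
Compound 3, `CC(C)=CCc1cc(C(=O)Nc2cc3ccc(OCCCNc4ccccc4)c(C)c3oc2=O)ccc1O`, gives > 50000 nM, which is a limit of the assay rather than a number.

Among the numbers shown, compound 1 and compound 2 sit together, with a 1.1-fold higher number from compound 1 to compound 2 (0.05 log units; within the scatter). Compound 4, `CC(C)=CCc1cc(C(=O)Nc2cc3ccc(OCCCN(C)c4ccccc4)c(C)c3oc2=O)ccc1O`, differs from compound 1 by 2-(methyl(phenyl)amino)ethyl in place of 1-methylpyrrolidin-3-yl on a saturated chain carbon bound to an oxygen on an aromatic ring. The measured steps that bear on this are an at least 54-fold higher number from compound 1 to compound 3 (1.73 log units; beyond the scatter) and an at least 48-fold higher number from compound 2 to compound 3 (1.68 log units; beyond the scatter), both large, and compound 4 likewise carries a phenyl on the amine nitrogen. A large rise in this assay is therefore expected for compound 4, quite possibly reaching (the limit of > 50000 nM in this assay, at which 1 of the 3 values shown sits). Compound 4 is estimated at 30000 nM, between 5000 nM and 120000 nM, an expected step of a 33-fold higher number from compound 1 to compound 4 (1.51 log units; beyond the scatter).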

Compound 4, half-maximal inhibitory concentration: > 50000 nM
Compound 4 was reported as a limit; the forecaster's own chance of this, stated with the estimate: 50%; middle value at least 1.6-fold (0.22 log units) from the limit.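

In this assay there is an at least 54-fold higher number from compound 1 to compound 4 (1.73 log units; beyond the scatter), and likewise an at least 48-fold higher number from compound 2 to compound 4 (1.68 log units; beyond the scatter), so methyl in place of hydrogen on the nitrogen carrying the phenyl does not restore the activity seen with compound 1 and compound 2. Compound 4 gives a limit, not a number, and the phenyl-bearing compounds now stand together there: the limit of > 50000 nM in this assay, at which 2 of the 4 values shown sit. The two limits leave the step from compound 3 to compound 4 unreadable, so the effect of that methyl cannot be sized.

Still open, on these data alone, is whether a phenyl directly on the amine nitrogen is what matters. A benzyl or cyclohexyl group on that nitrogen would test this.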